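The compounds below may be only part of what the source reports. "The series", "measured", "known", "first", "only" and "open" are said of these compounds alone.

Measured so far in an ADME assay on the whole organism with Oryza sativa as the target, tested at 10 uM; a higher number here means a weaker effect of the compound at the concentration tested, a lower number a stronger effect:
compound 1 `Cc1cccc(NC(=O)N[C@@H](C)c2ccccc2)c1` gives 100%
compound 2 `CCc1cccc(NC(=O)N[C@@H](C)c2ccccc2)c1` gives 86%
compound 3 `C[C@@H](NC(=O)Nc1cccc(F)c1)c1ccccc1` gives 84%

Compound 3 sits at the low end of these three numbers. Its gap to compound 1 is beyond the scatter, while its gap to compound 2 is within the scatter, so compound 2 and compound 3 cannot be ordered against each other. Among the compounds with values here, the only step between measured compounds is a number 14 percentage points lower from compound 1 to compound 2 (beyond the scatter), a change on the aryl ring of the shared core.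

The next compound, compound 4 `C[C@H](NC(=O)Nc1cccc(F)c1)c1ccccc1`, is the mirror counterpart of compound 3 at the one stereocentre: the two compounds have the same atoms and bonds and differ only in configuration as drawn: 1 of 1 stereo elements differ; a stereocentre at a saturated chain carbon is drawn R in compound 3 and S in compound 4.

Within the data shown here, no measured step bears on this change. The step from compound 1 to compound 2 concerns a substituent on the aryl ring and says nothing about inversion at the saturated chain carbon. Among the measured compounds shown here, in this series there is thus no precedent from which a direction could be read. The working expectation is that compound 4 stays close to compound 3, with an expected step of no change at the digits printed from compound 3 to compound 4 (within the scatter) in this assay, i.e. none beyond the scatter, though inversion of a stereocentre can in principle move a number either way. Compound 4 is estimated at 84%, with a range from 68% to 100%.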

Compound 4, a percentage reported as activity, at one concentration (the size of the read-out at that concentration, not a potency): 88%
Compound 4: middle estimate off by 4 percentage points, on the low side; low and high end bracket the measured number.
By their numbers in this assay, from the lowest: compounds 3, 2 and 4 (each within the scatter of the next); then compound 1.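

In this assay, the stereocentre at the saturated chain carbon now has a direct reading, a number 4 percentage points higher from compound 3 to compound 4 (within the scatter), so the R and S forms of the fluoro compound cannot be ordered, and this comparison isolates configuration alone: the fact that compounds 3 and 4 differ only in the configuration as drawn

Compound 4 also links the fluoro compounds to the earlier substituent comparison at the S configuration: fluoro in place of ethyl on an aromatic carbon gives a number 2 percentage points higher from compound 2 to compound 4 (within the scatter), whereas fluoro in place of methyl on an aromatic carbon gives a number 12 percentage points lower from compound 1 to compound 4 (beyond the scatter). Among these four compounds, only compound 1 is set apart from all the others by steps beyond the scatter, while compounds 2, 3 and 4 cannot be ordered among themselves.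

The compounds shown leave open whether inversion at the saturated chain carbon would read the same with methyl or ethyl in place of fluoro on the aromatic carbon. They also leave open how the series would respond to chloro, methoxy or trifluoromethyl in that place, or to a longer chain in place of the methyl on the saturated chain carbon.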